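The compounds below may be only part of what the source reports. "The series", "measured", "known", "first", "only" and "open" are said of these compounds alone.

Compound 1 `N#CC1=C(N)Oc2c(N)cc3nc4ccccc4nc3c2C12C(=O)N(Cc1cnnn1-c1cccc(C(F)(F)F)c1)c1ccccc12` and compound 2 `Cc1ccc(C)c(-n2nncc2CN2C(=O)C3(C(C#N)=C(N)Oc4c(N)cc5nc6ccccc6nc5c43)c3ccccc32)c1` share one core and differ only in the group on an aromatic nitrogen. In a functional assay on MCF7 cells (Homo sapiens) for antiproliferative activity, read by MTT assay, with a stated time of 48 h (a higher number here means a weaker inhibitor, a lower number a stronger inhibitor), compound 1 gives 31600 nM. In this assay compound 2 reaches only the limit of the assay, > 50000 nM, so no exact number is known for it (the limit of > 50000 nM in this assay, at which 1 of the 2 values shown sits). The step of an at least 1.5-fold higher number from compound 1 to compound 2 (0.19 log units; that floor lies within the scatter) is therefore a floor. Compound 3 `CCc1cccc(CC)c1-n1nncc1CN1C(=O)C2(C(C#N)=C(N)Oc3c(N)cc4nc5ccccc5nc4c32)c2ccccc21` carries the change (2,6-diethylphenyl in place of 2,5-dimethylphenyl on an aromatic nitrogen). Among the compounds with values here, the one measured step gives little guidance, so a step that the limit leaves unreadable from compound 2 to compound 3 is expected, and compound 3 is estimated at 60000 nM, between 20000 nM and 150000 nM, most likely again at the limit.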

Compound 3, half-maximal inhibitory concentration: > 50000 nM
Compound 3 was reported as a limit; the forecaster's own chance of this, stated with the estimate: 75%; the middle value is on the limit's open side.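

Within the data shown here, with 2,6-diethylphenyl on the aromatic nitrogen, compound 3 also ends at a limit in this assay, so a second replacement of 3-(trifluoromethyl)phenyl gives no exact number: the limit of > 50000 nM in this assay, at which 2 of the 3 values shown sit. The only readable comparison is an at least 1.5-fold higher number from compound 1 to compound 3 (0.19 log units; that floor lies within the scatter). The step between the two limits cannot be read, so 2,5-dimethylphenyl and 2,6-diethylphenyl cannot be ranked against each other.

On these data alone, it remains open whether a phenyl ring carrying an amine or a carboxylic acid would give a measurable value here, and how that value would compare with compound 1.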